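Amine swaps on the shared core: growth inhibition notes

This account rests on a few compounds, and the source may have more. Where it says the series, first, only, none or still open, it means among the compounds named here.

Measured compounds:
compound 1, `Cc1cc(=O)c2c(O)c(CN3CCN(C(=O)OC(C)(C)C)CC3)c(O)c([C@H]3CCN(C)C[C@H]3O)c2o1`: 1%
compound 2, `Cc1cc(=O)c2c(O)c(CN3CCCC3CO)c(O)c([C@H]3CCN(C)C[C@H]3O)c2o1`: 15%

In a functional assay on PC-3 cells (Homo sapiens) for inhibition, read by MTT assay, with a stated time of 48 h, tested at 10 uM (a higher number here means more inhibition of growth at the concentration tested, a lower number less inhibition of growth), compound 1 gives 1%, and compound 2 gives 15%. Compound 2 stands highest of the two numbers; its nearest neighbour is compound 1, and the gap between them lies beyond the scatter, so compound 2 is the more growth-inhibiting of the pair at the concentration tested. Both numbers are nonetheless low on the scale of this assay.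

Compound 3, `Cc1cc(=O)c2c(O)c(CN3CCCCC3)c(O)c([C@H]3CCN(C)C[C@H]3O)c2o1`, is not yet measured in this assay. It differs from compound 2 in one place: piperidin-1-yl in place of 2-(hydroxymethyl)pyrrolidin-1-yl on a saturated chain carbon bound to an aromatic carbon. Among the compounds with values here, no pair of measured compounds differing in a single place is available, so there is no measured step to set a scale for this change; the expectation rests on the low level of compound 2 alone, read as 15%.

The step of a number 5 percentage points lower from compound 2 to compound 3 (within the scatter) is expected to be small, downward, and not beyond the scatter. Compound 3 is expected to give about 10% in this assay, with a range from 0% to 28%.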

Compound 3, percent growth inhibition at one concentration: 14%
Compound 3: the middle estimate sits 4 percentage points below what was measured, within the range that was stated.
By their numbers in this assay, from the lowest: compound 1; then compounds 3 and 2 (each within the scatter of the next).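

In this assay, within the data shown here, the swap of 2-(hydroxymethyl)pyrrolidin-1-yl for piperidin-1-yl on a saturated chain carbon bound to an aromatic carbon reads as a number 1 percentage points lower from compound 2 to compound 3 (within the scatter), the first step that isolates a single change at this place. The group that enters has a six-membered rather than a five-membered ring and carries no hydrogen-bond donor, yet the number stays within the scatter, so at this place neither the hydroxymethyl branch nor the ring size registers as a difference on this low part of the scale. No supporting measurement is available to explain why the two groups read alike.

One step at a single concentration cannot show whether this insensitivity holds for other amines at the same place, such as morpholin-4-yl, dimethylamino or 4-methylpiperazin-1-yl. It also leaves open whether a longer chain between the aromatic carbon and the amine, or a carboxylic acid on the piperidine ring, would lift the number clear of this level.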